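The compounds below may be only part of what the source reports. "The series", "measured", "known", "first", "only" and "open" are said of these compounds alone.

Compound 1 `CCCCCCCCCCCCCCCCCCNC(=O)[C@H]1CSC(C2CCCCC2)N1` and compound 2 `CCCCCCCCCCCCCCCCCCNC(=O)[C@H]1CSC(c2cccc(O)c2)N1` share one core and differ at a single saturated ring carbon. In a functional assay on DU-145 cells (Homo sapiens) for antiproliferative activity, read by sulforhodamine B assay (a higher number here means a weaker inhibitor, a lower number a stronger inhibitor), compound 1 gives only a limit, > 20000 nM, not a number, as the limit of > 20000 nM in this assay, at which 1 of the 2 values shown sits, records. In this assay compound 2 gives 5700 nM. Within the data shown here, the measured step of an at least 3.5-fold lower number from compound 1 to compound 2 (0.54 log units; beyond the scatter) is the only one bearing on the change at hand, and it moved the number downward. Compound 3 `CCCCCCCCCCCCCCCCCCNC(=O)[C@H]1CSC(c2ccc(C#N)cc2)N1` differs from compound 1 by 4-cyanophenyl in place of cyclohexyl on a saturated ring carbon. A downward step of comparable size is therefore expected, an at least 2.8-fold lower number from compound 1 to compound 3 (0.45 log units; beyond the scatter). Compound 3 is estimated at 7000 nM, with a range from 2500 nM to 20000 nM.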

Compound 3, half-maximal inhibitory concentration: > 20000 nM
Compound 3 ended at the assay's limit (the forecaster's own chance of this, stated with the estimate: 30%); middle value at least 2.8-fold (0.45 log units) away from the limit.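

A phenyl ring on this carbon does not by itself bring measurable activity: putting 4-cyanophenyl in place of 3-hydroxyphenyl gives an at least 3.5-fold higher number from compound 2 to compound 3 (0.54 log units; beyond the scatter). The step from compound 1 to compound 3 cannot be read, as both values are limits. Only compound 2 gives an actual number, while the other two compounds share one limit: the limit of > 20000 nM in this assay, at which 2 of the 3 values shown sit.

On these data alone, what a 4-hydroxyphenyl or a 3-cyanophenyl group would give on this carbon stays open. The compounds shown therefore cannot separate the effect of swapping hydroxyl for nitrile from the effect of where that group sits on the phenyl ring.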